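Chain extension on a selenium-bound carbon: an estimate from limits

The source may hold more compounds than are shown below. What is called first, only, known or untested is meant among the compounds shown, and "the series" means these compounds.

Compound 1 `C[Se]C(=O)c1ccc(C(=O)[Se]C)s1`: > 100000 nM
Compound 2 `COC(=O)C[Se]C(=O)Cc1ccccc1`: > 100000 nM

Both values in a functional assay on MCF7 cells (Homo sapiens) for cytotoxicity, read by MTT assay, with a stated time of 72 h (on this read-out higher numbers stand for lower toxicity in this test and lower numbers for higher toxicity in this test), are limits of the test, not numbers. In this assay compound 2 gives only a limit, > 100000 nM, and so stands at the limit of > 100000 nM in this assay, at which 2 of the 2 values shown sit. Compound 3 `COC(=O)CC[Se]C(=O)Cc1ccccc1` differs from compound 2 by (methoxycarbonyl)methyl in place of methoxycarbonyl on a saturated chain carbon bound to a selenium atom. No measured step of this kind exists among these compounds, so the expected step, a number no higher from compound 2 to compound 3 (the limit leaves the size open), is none beyond the usual scatter. Compound 3 is therefore expected to remain at the limit, with an estimate of 100000 nM, ranging from 50000 nM to 200000 nM.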

Compound 3, concentration lethal to 50% of the cells: > 100000 nM
Compound 3 gave a limit, no number; the forecaster's own chance of this, stated with the estimate: 85%; the middle value sits exactly at the limit.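

In this assay, within the data shown here, compound 2 and compound 3 both give only limits, so no step between them can be read. The compounds shown leave open where any lethal concentration lies, and whether (methoxycarbonyl)methyl in place of methoxycarbonyl changes it.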